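A few compounds are considered here, and "the series" means these few. Any claim that something is new, unique, unknown or untested is made for them only; others in the source may bear on it.

Measured in a functional assay on ECV-304 cells (Homo sapiens), read by MTT assay, with stated times of 24 h and 12 h; on this read-out lower numbers stand for an effect already at smaller amounts and higher numbers for an effect only at larger amounts of compound:
compound 1 `COC(=O)c1ccc(OCc2nc(C)c(C)nc2C)c(OC)c1`: 3200000 nM
compound 2 `Cc1nc(C)c(COc2ccccc2C(=O)O)nc1C`: 610000 nM
compound 3 `C=CCSSCc1nc(C)c(C)nc1C`: 1100000 nM

Compound 1 has the highest number of the three, so it needs the largest amount to show an effect. Compound 3 lies nearest to it and compound 2 furthest, and both gaps go beyond the usual scatter of repeated measurements.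

The next compound, compound 4 `C=CCc1ccc(OCc2nc(C)c(C)nc2C)c(OC)c1`, has allyl in place of methoxycarbonyl on an aromatic carbon. Going by the values given here, no two measured compounds differ in only one place, so this assay offers no direct precedent for this change. The expectation rests only on the spread of values: compound 1 gives 3200000 nM, compound 3 gives 1100000 nM and compound 2 gives 610000 nM, so the numbers of compound 3 and compound 2 both lie lower than that of compound 1. A compound at the top of such a small set seems more likely to be followed by a lower number than a higher one. The expected change is modest, an estimated 2.5-fold lower number from compound 1 to compound 4 (0.39 log units; beyond the scatter). For compound 4 the estimated value is 1300000 nM, with an expected range from 400000 nM to 3500000 nM.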

Compound 4, half-maximal effective concentration: 200000 nM
Compound 4: middle estimate off by 6.5-fold (0.81 log units), on the high side; measured number below the stated range.
By their numbers in this assay, from the lowest: compound 4; then compounds 2 and 3 (each within the scatter of the next); then compound 1.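

In this assay, going by these compounds alone, allyl in place of methoxycarbonyl on this aromatic carbon gives a 16-fold lower number from compound 1 to compound 4 (1.20 log units; beyond the scatter) and is the first direct comparison, with only one place differing. The step is large, so the group on this carbon, para to a large group and meta to a methoxy group, clearly matters to how much compound is needed for an effect. By the counts, methoxycarbonyl brings oxygen and hydrogen-bond acceptors while allyl brings neither, but no measurement links that difference to the step.

A single pair cannot separate what allyl adds from what the loss of methoxycarbonyl removes. Going by these compounds, how an amine, a carboxylic acid or a longer carbon chain on this same aromatic carbon would compare with allyl remains open.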